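The source may report more compounds than this note shows. Statements on the series, on what has been measured and on what is new or still open speak of the compounds shown alone.

Compound 3 `OC[C@@H]1CCCN1c1ncnc2sc(Nc3ccc(Cl)cc3)nc12` is the starting point of this step. In a functional assay on CHO-K1 cells for antagonist activity at adenosine receptor A2b (Homo sapiens), read by 33P incorporation, with a stated time of 20 min, in the presence of a further agent that is not named here (a lower number here means a stronger inhibitor, a higher number a weaker inhibitor), compound 3 gives > 10000 nM, which is a limit of the assay and not a number. Compound 1 `Clc1ccc(Nc2nc3c(N4CCCC4)ncnc3s2)cc1` carries hydrogen where compound 3 carries hydroxymethyl on the saturated ring carbon. In this assay compound 1 gives > 10000 nM, again a limit. Compound 2 `Cc1ccc(Nc2nc3c(N4CCCC4)ncnc3s2)cc1` carries methyl where compound 1 carries chloro on the aromatic carbon. In this assay compound 2 gives > 10000 nM, also a limit. Compound 3 thus stands where every measured compound stands, at the limit of > 10000 nM in this assay, at which 3 of the 3 values shown sit, and neither a step that the two limits leave unreadable from compound 1 to compound 2 nor a step that the two limits leave unreadable from compound 1 to compound 3 can be given a size.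

Compound 4 `Cc1ccc(Nc2nc3c(N4CCC[C@H]4CO)ncnc3s2)cc1` is the compound still to be measured, and it differs from compound 3 by methyl in place of chloro on an aromatic carbon. Among the compounds with values here, the one measured step that bears on this exchange is a step that the two limits leave unreadable from compound 1 to compound 2, the same swap on the same kind of ring carbon, whose size could not be read because both of its ends sit at the limit of > 10000 nM in this assay, at which 3 of the 3 values shown sit. The step from compound 3 to compound 4 is therefore expected to be a number no higher from compound 3 to compound 4 (the limit leaves the size open), meaning no readable change in this assay. Compound 4 is estimated at 10000 nM, with a range from 3000 nM to 40000 nM, and it is expected that this assay will most likely again report only a limit for compound 4.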

Compound 4, inhibition constant: > 10000 nM
Compound 4: a limit, no number; the forecaster's own chance of this, stated with the estimate: 85%; the middle value lies on the limit itself.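

In this assay compound 4 gives > 10000 nM as a limit of the assay and not a number. Within the data shown here, no step to compound 4 from compound 3 or from compound 2 can therefore be read. The compounds shown leave open what either exchange, chloro to methyl or hydrogen to hydroxymethyl, does to the inhibition constant, as compounds 1, 2, 3 and 4 all share one limit: the limit of > 10000 nM in this assay, at which 4 of the 4 values shown sit.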